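The source may hold more compounds than are shown below. What is called first, only, known or untested is meant among the compounds shown, and "the series" means these compounds.

Series notes. Two compounds sharing one core have been run in a functional assay on MOLT-4 cells (Homo sapiens) for cytotoxicity, read by CCK-8 assay, with a stated time of 72 h; a lower number here means a stronger inhibitor, a higher number a weaker inhibitor. Compound 1 `C=CCn1c(=O)/c(=C\c2ccccc2F)[nH]c(=O)/c1=C\c1ccccc1OC` gives 20000 nM in this assay, and compound 2 `C=CCn1c(=O)/c(=C\c2cccc(Cl)c2)[nH]c(=O)/c1=C\c1ccccc1OC` gives 4900 nM. Among the compounds with values here, the only step so far, a 4.1-fold lower number from compound 1 to compound 2 (0.61 log units; beyond the scatter), shows that exchanging the aryl group on the double-bonded chain carbon moves the number beyond the scatter. On the two numbers at hand, compound 2 stands at the lowest, with compound 1 as its nearest neighbour at a higher number.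

Compound 3 `C=CCn1c(=O)/c(=C\c2ccc(C)cc2)[nH]c(=O)/c1=C\c1ccccc1OC` is not yet measured. It differs from compound 2 as follows: 4-methylphenyl in place of 3-chlorophenyl on a double-bonded chain carbon bound to an aromatic carbon

Only a 4.1-fold lower number from compound 1 to compound 2 (0.61 log units; beyond the scatter) bears on this change, and it concerns a different pair of aryl groups, so it sets the scale of what an aryl swap at this place can do rather than the direction. For compound 3 the expectation is a step of about a 1.3-fold higher number from compound 2 to compound 3 (0.12 log units; within the scatter), within or near the scatter. Compound 3 is therefore estimated at 6500 nM, with a range from 2000 nM to 20000 nM.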

Compound 3, half-maximal inhibitory concentration: "not active" (no number reported)
Compound 3 has no reported number here, and the estimate cannot be compared.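

Within the data shown here, compound 3 is reported as "not active" without a number in this assay, so no step from compound 2 to compound 3 can be read. The compounds shown leave open how 4-methylphenyl compares numerically with 3-chlorophenyl at this place. Nothing available bears on this result.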